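This account rests on a few compounds, and the source may have more. Where it says the series, first, only, none or still open, it means among the compounds named here.

Of the compounds shown here, three built on one shared core have been tested in an assay for inhibition of Polyunsaturated fatty acid 5-lipoxygenase (Homo sapiens), read by HPLC, with a stated time of 10 min; a higher number here means a weaker inhibitor, a lower number a stronger inhibitor. Compound 1 `CCCCC(Sc1nc(Cl)cc(Nc2nc(-c3ccc(Cl)cc3)cs2)n1)C(=O)O` gives 3800 nM in this assay. Compound 2 `O=C(O)CSc1nc(Cl)cc(Nc2nc(-c3ccc(Cl)cc3)cs2)n1` reaches only the limit of this assay, > 10000 nM, so for it no number is known. Going by the values given here, the one step between compounds that differ in a single place, an at least 2.6-fold higher number from compound 1 to compound 2 (0.42 log units; beyond the scatter), shows that removing the butyl from the carbon that bears the acid weakens inhibition, with compound 2 sitting at the limit (the limit of > 10000 nM in this assay, at which 1 of the 3 values shown sits). Compound 3 `CCCCCCC(Sc1nc(Cl)cc(Nc2nc(-c3ccc(C)cc3)cs2)n1)C(=O)O` gives 3000 nM in this assay, the lowest of the two numbers, and compound 1 is its nearest neighbour, within the scatter, so the two cannot be ranked against each other.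

Compound 4 `CCCCCCC(Sc1nc(Cl)cc(Nc2nc(-c3ccc(F)cc3F)cs2)n1)C(=O)O` has not been measured. It differs from compound 3 in one place: 2,4-difluorophenyl in place of 4-methylphenyl on an aromatic carbon. Among the compounds with values here, no measured step touches this position: the only step on record concerns the saturated carbon bound to the carbonyl carbon and the sulfur, not the aromatic group on the five-membered ring, so nothing in the data points to a change in either direction beyond the scatter. Compound 4 is therefore expected to give about 3000 nM in this assay, with a range from 1200 nM to 8000 nM, an expected step of no change at the digits printed from compound 3 to compound 4 (within the scatter).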

Compound 4, half-maximal inhibitory concentration: 2500 nM
Compound 4: middle estimate off by 1.2-fold (0.08 log units), on the high side; low and high end bracket the measured number.
By their numbers in this assay, from the lowest: compounds 4, 3 and 1 (each within the scatter of the next). At a limit, above all of these: compound 2.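

Going by these compounds alone, this is the first measured step at the aromatic group on the five-membered ring, and in this assay it reads a 1.2-fold lower number from compound 3 to compound 4 (0.08 log units; within the scatter). At this aromatic carbon next to the ring nitrogen, then, a group of 8 heavy atoms, 2 of them fluorine, can take the place of a group of 7 carbon atoms with no difference that can be told from the scatter, so this one exchange leaves inhibition where it was. Nothing on record bears on why the two groups read alike.

The compounds shown leave open whether a phenyl ring with no substituent, one carrying an amine or a methoxy group, or a larger ring such as naphthyl would also leave the number in place, since only this one exchange has been read here on the same chain. Compound 1 and compound 3 differ in two places, so the length of the chain on the carbon that bears the acid remains unseparated from the aromatic group, and a chain longer than those shown, or an amide in place of the carboxylic acid, remains untested in these data.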